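The source may hold more compounds than are shown below. What is called first, only, known or untested is meant among the compounds shown, and "the series" means these compounds.

Of the compounds shown here, three that share a core have been measured in a functional assay on MDA-MB-231 cells (Homo sapiens) for inhibition, with a stated time of 72 h; on this read-out lower numbers stand for stronger inhibition and higher numbers for weaker inhibition. Compound 2, `O=C(Nc1ccc(Cl)cc1)Nc1nc(Sc2c[nH]c3ccccc23)cc(N2CCCC2)n1`, gives 5850 nM, and compound 3, `O=C(Nc1ccc(Cl)cc1)Nc1nc(Sc2c[nH]c3ccccc23)cc(N2CCCCC2)n1`, gives 10100 nM. Compound 1, `Cc1cc(Cl)ccc1NC(=O)Nc1nc(Sc2c[nH]c3ccccc23)cc(N2CCN(Cc3ccccc3)CC2)n1`, gives 22100 nM. Compound 2 therefore sits at the low end of these numbers, level within the scatter with compound 3 and clearly apart from compound 1.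

The next compound is compound 4, `COc1ccc(NC(=O)Nc2nc(Sc3c[nH]c4ccccc34)cc(N3CCCC3)n2)cc1`, which is compound 2 with one small edit: methoxy in place of chloro on an aromatic carbon. In words, methoxy takes the place of chloro, turning 4-chlorophenyl into 4-methoxyphenyl.

Going by the values given here, no measured step changes this group on its own, so the data give no direct size for this edit. Compound 1 differs from compound 2 in more than one place, so its value cannot be assigned to any single change. Among the compounds with values here, the only single-place step is a 1.7-fold higher number from compound 2 to compound 3 (0.24 log units; within the scatter), and it concerns a different part of the molecule, with piperidin-1-yl in place of pyrrolidin-1-yl. Within the data shown here, with only that small step as a guide, no clear direction can be argued, and no shift beyond the scatter is expected in this assay.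

The expected change is a 1.2-fold higher number from compound 2 to compound 4 (0.08 log units; within the scatter). The estimated value for compound 4 is 7000 nM, with an expected range from 2500 nM to 20000 nM.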

Compound 4, half-maximal inhibitory concentration: 13100 nM
For compound 4 the middle estimate is 1.9-fold (0.27 log units) below the measured one; low and high end bracket the measured number.
By their numbers in this assay, from the lowest: compounds 2, 3, 4 and 1 (each within the scatter of the next, the first and the last beyond it).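

In this assay, going by these compounds alone, the group on the phenyl ring is the first place where a single edit is seen to move the number beyond the scatter: the change of chloro to methoxy gives a 2.2-fold higher number from compound 2 to compound 4 (0.35 log units; beyond the scatter) on the same pyrrolidin-1-yl background. Within the data shown here, the one earlier single-place step, a 1.7-fold higher number from compound 2 to compound 3 (0.24 log units; within the scatter) for piperidin-1-yl in place of pyrrolidin-1-yl, stayed within the scatter, so it could not show that any single place in these compounds matters. The new step is modest and rests on a single pair, but in that pair 4-chlorophenyl goes with the lower number and 4-methoxyphenyl with the higher one, and no measurement available here explains this direction.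

As far as these compounds go, it remains open whether the same edit gives a step of similar size and direction when piperidin-1-yl replaces pyrrolidin-1-yl elsewhere on the molecule. Also open, from the compounds shown here alone, is where other groups at this position would fall relative to chloro and methoxy, for example fluoro, a nitrile, a hydroxyl or a dimethylamino group, and whether any of them would give a lower number than chloro.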